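The source may hold more compounds than are shown below. What is called first, only, known or untested is meant among the compounds shown, and "the series" means these compounds.

Of the compounds shown here, two of this small series have already been measured. Compound 1 `ClCc1ccc(Cn2cnc3c(Cl)ncnc32)cc1` gives 3800 nM in a functional assay on ACHN cells (Homo sapiens) for cytotoxicity, read by sulforhodamine B assay, with a stated time of 48 h; a higher number here means that more compound is tolerated, a lower number that less compound is tolerated. Compound 2 `ClCc1ccccc1Cn1cnc2c(Cl)nc(Cl)nc21` gives 4160 nM in this assay, and although that is the higher of the two numbers, the gap to compound 1 lies within the scatter, so the two compounds stand together and nothing separates them on the evidence so far. Among the compounds with values here, no pair of measured compounds differing in one place is available, so no measured step can guide the next move.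

Compound 3 `ClCc1ccccc1Cn1cnc2c(Cl)ncnc21` has not yet been measured. It differs from compound 2 by hydrogen in place of chloro on an aromatic carbon. Within the data shown here, with only two compounds in hand, and those two indistinguishable from each other, there is no measured basis for expecting the removal of this chloro group to shift the number one way or the other. The expected step from compound 2 to compound 3 is therefore a 1.0-fold lower number from compound 2 to compound 3 (0.02 log units; within the scatter), that is, no change beyond the scatter. On that basis compound 3 is estimated at 4000 nM, within a range from 1500 nM to 11000 nM, and the measurement will show whether this expectation holds.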

Compound 3, concentration lethal to 50% of the cells: 26900 nM
Estimate against measurement, compound 3: 6.7-fold (0.83 log units) below, outside the stated range (above it).
By their numbers in this assay, from the lowest: compounds 1 and 2 (each within the scatter of the next); then compound 3.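

Within the data shown here, the step at the aromatic carbon between two ring nitrogen atoms is the first measured change, and it shows that this position is not indifferent in this assay. Hydrogen in place of chloro there gives a 6.5-fold higher number from compound 2 to compound 3 (0.81 log units; beyond the scatter), so more of the compound without the chloro group is tolerated, and the loss of this single heavy atom is enough to move the number beyond the scatter, which the close numbers of compound 1 and compound 2 could not reveal. The data offer no measured property that would account for this step.

From the compounds shown here alone, it remains open whether the chloro group itself matters or whether another group at this carbon, such as an amine, a methoxy group or a bromo group, would keep the number near that of compound 2 or let it rise towards that of compound 3. Going by these compounds, it is also open whether the same exchange would have a similar size on the arrangement of compound 1, whose chloromethyl-bearing benzene ring differs from that of compound 3.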